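Amine variation on the thiocarbonyl carbon: estimate for compound 4

The source may report more compounds than this note shows. Statements on the series, on what has been measured and on what is new or still open speak of the compounds shown alone.

Measured in a functional assay on MGC-803 cells (Homo sapiens) for antiproliferative activity, read by CCK-8 assay, with a stated time of 72 h, tested at 2 uM (on this read-out lower numbers stand for a weaker effect and higher numbers for a stronger effect at the one concentration tested), so far:
compound 1 `CCN(Cc1ccncc1)C(=S)SCc1ccc(C(=O)Nc2ccccc2N)cc1` gives 71.6%
compound 2 `CN(Cc1cccnc1)C(=S)SCc1ccc(C(=O)Nc2ccccc2N)cc1` gives 45.9%
compound 3 `Nc1ccccc1NC(=O)c1ccc(CSC(=S)N2CCN(c3ccccc3F)CC2)cc1` gives 33.7%

Compound 2 stands second highest of the three numbers. Its nearest neighbour is compound 3, which lies lower by more than the scatter; compound 1 lies higher by more than the scatter.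

Compound 4 `Nc1ccccc1NC(=O)c1ccc(CSC(=S)N2CCCC2)cc1` has not been measured. It differs from compound 2 in one place: pyrrolidin-1-yl in place of methyl((pyridin-3-yl)methyl)amino on a thiocarbonyl carbon.

Going by the values given here, only one measured step changes the amine on the thiocarbonyl carbon while the rest of the shared core stays the same, and it is a number 25.7 percentage points lower from compound 1 to compound 2 (beyond the scatter). That single step shows that the amine portion alone can shift the read-out by a modest amount beyond the scatter. The pairing of compound 2 with compound 3 is not a single-place step, but the two values together point the same way: a different amine on the thiocarbonyl carbon goes with a different number. Among the compounds with values here, no measured step carries a pyrrolidin-1-yl group, so the direction for compound 4 is not fixed by the data; the change removes the only ring and acceptor of the departing group, and the numbers seen so far have moved downward when the amine was changed from compound 1.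

Compound 4 is therefore expected to fall somewhat below compound 2 in this assay, by a step of roughly a number 9.9 percentage points lower from compound 2 to compound 4 (within the scatter). The estimate for compound 4 is 36%, with a range from 18% to 56%.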

Compound 4, a percentage reported as inhibition, at one concentration (the size of the read-out at that concentration, not a potency): 27%
Compound 4: the middle estimate sits 9 percentage points above what was measured; the measured number falls inside the stated range.
By their numbers in this assay, from the lowest: compounds 4 and 3 (each within the scatter of the next); then compound 2; then compound 1.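

In this assay, going by these compounds alone, pyrrolidin-1-yl in place of methyl((pyridin-3-yl)methyl)amino on a thiocarbonyl carbon gives a first reading for an amine without a six-membered aromatic ring (a number 18.9 percentage points lower from compound 2 to compound 4 (beyond the scatter)), and in place of ethyl((pyridin-4-yl)methyl)amino it gives the largest step seen at this position (a number 44.6 percentage points lower from compound 1 to compound 4 (beyond the scatter)). Among compound 1, compound 2 and compound 4, the two amines holding a pyridine ring therefore read higher than pyrrolidin-1-yl, but a larger amine alone does not secure a high number: compound 3 goes against that reading, at only 33.7%. No supporting data are available to explain these differences.

From the compounds shown here alone, it remains open whether the ethyl or methyl group or the pyridin-4-yl or pyridin-3-yl attachment accounts for the earlier step (a number 25.7 percentage points lower from compound 1 to compound 2 (beyond the scatter)), as both change together in that pair. Also open, going by these compounds, is how a diethylamino, morpholin-4-yl or benzyl(methyl)amino group would read on the same thiocarbonyl carbon, the last of these holding an aromatic ring without a ring nitrogen.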